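The source may report more compounds than this note shows. Statements on the series, on what has been measured and on what is new or still open speak of the compounds shown alone.

In an assay on isolated protein for inhibition of Leucine-rich repeat serine/threonine-protein kinase 2 variant G2019S (Homo sapiens), read by TR-FRET and LanthaScreen, with stated times of 50 min and 30 min, in the presence of a further agent that is not named here (a lower number here means a stronger inhibitor, a higher number a weaker inhibitor), compound 3 `Cc1nn(C)cc1Nc1nc(N)c2c(C#N)c(N3CCC[C@H]3C)n(C)c2n1` gives 30 nM, the smallest number of the three measured, though neither neighbour is separated from it beyond the scatter: compound 2 `Cc1c(Nc2nc(N)c3c(C#N)c(N4CCC[C@H]4C)n(C)c3n2)cnn1CC(C)(C)O` gives 35 nM and compound 1 `Cc1nn(CC2(O)COC2)cc1Nc1nc(N)c2c(C#N)c(N3CCC[C@H]3C)n(C)c2n1` gives 51 nM. Going by the values given here, the one measured step, a 1.7-fold lower number from compound 1 to compound 3 (0.23 log units; within the scatter), concerns the chain on the aromatic nitrogen and not the aromatic carbon changed here. Compound 4 `C[C@@H]1CCCN1c1c(C#N)c2c(N)nc(Nc3cn(C)nc3C(F)(F)F)nc2n1C` differs from compound 3 by trifluoromethyl in place of methyl on an aromatic carbon. Among the compounds with values here, no measured pair touches this methyl, so the only guide is that the ring substituents explored so far moved the number little; for compound 4 a step of a 1.3-fold higher number from compound 3 to compound 4 (0.12 log units; within the scatter) is expected, none beyond the scatter, with an estimated 40 nM and a range from 12 nM to 150 nM.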

Compound 4, half-maximal inhibitory concentration: 358 nM
Compound 4: the middle estimate sits 9.0-fold (0.95 log units) below what was measured, and the stated range ends below it.
By their numbers in this assay, from the lowest: compounds 3, 2 and 1 (each within the scatter of the next); then compound 4.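

In this assay, trifluoromethyl in place of methyl on this aromatic carbon gives a 12-fold higher number from compound 3 to compound 4 (1.08 log units; beyond the scatter) and is the first step beyond the scatter among the compounds shown. The number therefore responds to the group on this carbon, whereas the change in the chain on the aromatic nitrogen gave only a 1.7-fold lower number from compound 1 to compound 3 (0.23 log units; within the scatter) and stayed within the scatter. No measurement shown explains this rise.

Still open, on these data alone, is how the number behaves with hydrogen, ethyl or chlorine on this carbon, and whether the same change has a similar effect alongside the other chains on the aromatic nitrogen.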